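Carbamoyl-bearing ring changed from phenyl to pyridyl

The source may hold more compounds than are shown below. What is called first, only, known or untested is meant among the compounds shown, and "the series" means these compounds.

Measured compounds:
compound 1, `Nc1ccccc1-c1cnc(C(=O)CCCCCCc2ccccc2)o1` — 750 nM
compound 2, `O=C(CCCCCCc1ccccc1)c1ncc(-c2ccc(O)cc2)o1` — 140 nM
compound 3, `NC(=O)c1ccc(-c2cnc(C(=O)CCCCCCc3ccccc3)o2)cc1` — 10 nM

In an assay (Rattus norvegicus) for inhibition of Fatty-acid amide hydrolase 1 (Homo sapiens) (a lower number here means a stronger inhibitor, a higher number a weaker inhibitor), compound 3 has the lowest number of the three. One of the two steps that lead to it is a 14-fold lower number from compound 2 to compound 3 (1.15 log units; beyond the scatter), and the other is a 75-fold lower number from compound 1 to compound 3 (1.88 log units; beyond the scatter); both steps lie beyond the scatter, so compound 3 is the strongest inhibitor of the three.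

Compound 4, `NC(=O)c1ccc(-c2cnc(C(=O)CCCCCCc3ccccc3)o2)nc1`, is not yet measured. It differs from compound 3 in one place: 5-carbamoylpyridin-2-yl in place of 4-carbamoylphenyl on an aromatic carbon. The measured steps change the group on the ring that carries the carbamoyl, not the ring itself, so none of them bears directly on this change. What they do show is that the carbamoyl group accounts for the gain from compound 2 to compound 3, a 14-fold lower number from compound 2 to compound 3 (1.15 log units; beyond the scatter), and that group is kept in compound 4. Among the compounds with values here, with the carbamoyl retained and no measured step covering a phenyl-to-pyridyl exchange, the author expects compound 4 to stay close to compound 3, with a step of a 1.5-fold higher number from compound 3 to compound 4 (0.18 log units; within the scatter) that would not exceed the scatter. The estimate for compound 4 in this assay is 15 nM, expected between 4 nM and 50 nM.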

Compound 4, inhibition constant: 1.2 nM
Compound 4: middle estimate off by 13-fold (1.10 log units), on the high side; measured number outside the range, below it.
By their numbers in this assay, from the lowest: compound 4; then compound 3; then compound 2; then compound 1.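

In this assay, the ring that carries the carbamoyl matters as well as the carbamoyl itself: with that group kept, 5-carbamoylpyridin-2-yl in place of 4-carbamoylphenyl gives an 8.3-fold lower number from compound 3 to compound 4 (0.92 log units; beyond the scatter), a step beyond the scatter. The other two compounds fall further behind, with a 120-fold lower number from compound 2 to compound 4 (2.07 log units; beyond the scatter) and a 630-fold lower number from compound 1 to compound 4 (2.80 log units; beyond the scatter), so compound 4 is the strongest inhibitor of the four. Nothing shown explains what the hetero atom in the ring contributes to this gain.

The compounds shown leave open whether a nitrile or a carboxylic acid in place of the carbamoyl on the pyridyl ring would keep this gain, and whether a pyrimidinyl ring would extend it. They also leave open whether an unsubstituted pyridyl ring would show any gain without the carbamoyl.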